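Swapping Methoxy for Chloro on a Chalcone Scaffold

A few compounds are considered here, and "the series" means these few. Any claim that something is new, unique, unknown or untested is made for them only; others in the source may bear on it.

In a functional assay on HepG2 cells (Homo sapiens) for antiproliferative activity, read by MTT assay, with a stated time of 24 h (on this read-out higher numbers stand for weaker inhibition and lower numbers for stronger inhibition), compound 1 `COc1cccc(/C=C/C(=O)c2ccc(OC)c3c2OC(C)(C)C=C3)c1` gives only the limit of the assay, > 10000 nM. Compound 2 `COc1ccc(C(=O)/C=C/c2ccc(N(c3ccccc3)c3ccccc3)cc2)c2c1C=CC(C)(C)O2` likewise reaches only the limit, > 10000 nM, in this assay. The two values shown both sit at the limit of > 10000 nM in this assay, at which 2 of the 2 values shown sit. Compound 3 `COc1ccc(C(=O)/C=C/c2cccc(Cl)c2)c2c1C=CC(C)(C)O2` differs from compound 1 in one place: chloro in place of methoxy on an aromatic carbon. For the measured compounds named here, no measured pair with this change exists here, so the size of any shift stays open; the step that the limit leaves unreadable from compound 1 to compound 3 is expected to stay within the usual scatter. Compound 3 is estimated at 20000 nM, with a range from 5000 nM to 80000 nM, and a result reported only as a limit is expected to be likely.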

Compound 3, half-maximal inhibitory concentration: > 10000 nM
Compound 3 was reported as a limit; the forecaster's own chance of this, stated with the estimate: 65%; the middle value is on the limit's open side.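

For the compounds shown here, compound 1 and compound 3 are both reported only as limits in this assay, and no step between them can be read. The compounds shown leave open whether swapping methoxy for chloro changes inhibition at all.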